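From a Methoxy Group to a Diethylcarbamoyl Group

This account rests on a few compounds, and the source may have more. Where it says the series, first, only, none or still open, it means among the compounds named here.

Compound 3 `COC1CCC(N(Cc2ccc(C(=O)NCCC(=O)O)cc2)C(=O)Nc2ccc(OC(F)(F)F)cc2)CC1` carries a methoxy group on a saturated ring carbon of its core. In an in vitro assay on BHK cells for inhibition of Glucagon receptor (Homo sapiens) (on this read-out higher numbers stand for weaker inhibition and lower numbers for stronger inhibition), compound 3 gives > 10000 nM, which is a limit of the assay and not a number. Compound 1 `O=C(O)CCNC(=O)c1ccc(CN(C(=O)Nc2ccc(OC(F)(F)F)cc2)C2CCC(C(=O)NCC3CC3)CC2)cc1` also stops at the limit > 10000 nM in this assay. Compound 2 `O=C(O)CCNC(=O)c1ccc(CN(C(=O)Nc2ccc(OC(F)(F)F)cc2)C2CCC(C(=O)O)CC2)cc1` likewise reaches only the limit > 10000 nM. Because of the limit of > 10000 nM in this assay, at which 3 of the 3 values shown sit, the steps a step that the two limits leave unreadable from compound 1 to compound 2, a step that the two limits leave unreadable from compound 1 to compound 3 and a step that the two limits leave unreadable from compound 2 to compound 3 cannot be read in size or direction. Compound 4 `CCN(CC)C(=O)C1CCC(N(Cc2ccc(C(=O)NCCC(=O)O)cc2)C(=O)Nc2ccc(OC(F)(F)F)cc2)CC1` differs from compound 3 by diethylcarbamoyl in place of methoxy on a saturated ring carbon. Among the measured compounds shown here, compound 1 already holds a (cyclopropylmethyl)carbamoyl group on that ring carbon, and no measured step shows a readable gain from such a group. Compound 4 is therefore expected to stay near the same limit, an estimated step of a number no higher from compound 3 to compound 4 (the limit leaves the size open), with an expected value of 10000 nM and a range from 3000 nM to 30000 nM.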

Compound 4, half-maximal inhibitory concentration: 782 nM
The estimate for compound 4 lay 13-fold (1.11 log units) above the measured number; measured number below the stated range.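

Among the compounds shown here, on this saturated ring carbon, diethylcarbamoyl gives the first readable number in this assay, with an at least 12-fold lower number from compound 3 to compound 4 (1.10 log units; beyond the scatter). A carbonyl carbon alone does not account for this: with diethylamino in place of hydroxy there is an at least 12-fold lower number from compound 2 to compound 4 (1.10 log units; beyond the scatter), and with diethylamino in place of (cyclopropylmethyl)amino there is an at least 12-fold lower number from compound 1 to compound 4 (1.10 log units; beyond the scatter), so the group on the carbonyl carbon matters. Each of these steps gives only a minimum size: the limit of > 10000 nM in this assay, at which 3 of the 4 values shown sit.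

The compounds shown leave open how much depends on the two ethyl groups. A dimethylamino or dipropylamino group on the same carbonyl carbon would test this.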